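A Shorter Triple-Bond Amide on the Core of Compound 1

The compounds below may be only part of what the source reports. "The series", "measured", "known", "first", "only" and "open" are said of these compounds alone.

- Compound 1 `CC#CCNC(=O)c1cccc2c1cc(C)n2-c1nc2c(c(NCc3ccccc3)n1)COCC2`: > 24 h (a limit)
- Compound 2 `C#CC(=O)Nc1cccc2c1cc(C)n2-c1nc2c(c(NCc3ccccc3)n1)CCCC2`: 0.21 h
- Compound 3 `C=CC#CC(=O)Nc1cccc2c1cc(C)n2-c1nc2c(c(NCc3ccccc3)n1)CCCC2`: 5.08 h

In a physicochemical assay for pharmacokinetics, read by LC-MS, in phosphate buffer, tested at 1 uM (on this read-out higher numbers stand for a longer-lived compound and lower numbers for a shorter-lived compound), compound 1 gives > 24 h, which is a limit and not a number. It stands at the limit of > 24 h in this assay, at which 1 of the 3 values shown sits.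

Compound 4 `CC#CC(=O)Nc1cccc2c1cc(C)n2-c1nc2c(c(NCc3ccccc3)n1)COCC2` has not yet been measured. It departs from compound 1 at a single place: a group of 6 heavy atoms (4 carbon, 1 nitrogen, 1 oxygen; no ring) in place of a group of 7 heavy atoms (5 carbon, 1 nitrogen, 1 oxygen; no ring), on an aromatic carbon. The group that enters is ((prop-1-yn-1-yl)carbonyl)amino, on an aromatic carbon.

Within the data shown here, one measured step bears on this change, and only indirectly. It is a 24-fold higher number from compound 2 to compound 3 (1.38 log units; beyond the scatter), a large step beyond the scatter, with vinyl in place of hydrogen on a triple-bonded carbon. Among the measured compounds shown here, the entering group also has a triple-bonded carbon without hydrogen, but no measured compound carries this group, and no step has been measured on the core of compound 1. The expectation therefore rests on compound 3 at 5.08 h and on that single step, and it points to a shorter-lived compound.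

The expected change is an at least 1.6-fold lower number from compound 1 to compound 4 (0.20 log units; that floor lies within the scatter), although a result reported only as a limit remains possible. For compound 4 the estimated half-life is 15 h, with an expected range of 5 h to 45 h.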

Compound 4, half-life: 16.2 h
Beside the measured number, compound 4's estimate is 1.1-fold (0.03 log units) below it, within the range that was stated.
By their numbers in this assay, from the lowest: compound 2; then compound 3; then compound 4. At a limit, above all of these: compound 1.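

In this assay compound 4 gives 16.2 h, so the core of compound 1 now carries, on this aromatic carbon, a group whose half-life reads as a number. Placing ((prop-1-yn-1-yl)carbonyl)amino there in place of the larger group gives an at least 1.4-fold lower number from compound 1 to compound 4 (0.17 log units; that floor lies within the scatter), and this is a floor only, which leaves the true size of the step unfixed. Compound 1 stands at a limit and not at a number, and the step can therefore go no further than that floor: the limit of > 24 h in this assay, at which 1 of the 4 values shown sits.

As far as these compounds go, it remains open how ((prop-1-yn-1-yl)carbonyl)amino would read on the core shared by compound 2 and compound 3, and whether the vinyl step seen there, a 24-fold higher number from compound 2 to compound 3 (1.38 log units; beyond the scatter), would carry over to the core of compound 1. Also open, from the compounds shown here alone, is what a propanoylamino group, with a saturated chain in place of the triple bond, or a longer chain such as a pentynoylamino group, would give on this same aromatic carbon.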